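This account rests on a few compounds, and the source may have more. Where it says the series, first, only, none or still open, it means among the compounds named here.

Two measured compounds stand in an assay on cells for inhibition of MAP kinase-interacting serine/threonine-protein kinase 1 (Homo sapiens), read by mobility shift assay, with stated times of 10 min and 60 min, in the presence of a further agent that is not named here; on this read-out higher numbers stand for weaker inhibition and lower numbers for stronger inhibition. Compound 1 `NC(=O)c1ccc(-c2cccnc2)cc1OC1CCNC1` gives 1900 nM, the lower of the two numbers. Compound 2 `NC(=O)c1ccc(-c2ccc(N)nc2)cc1` gives 34000 nM in this assay; it differs from compound 1 in more than one place, so the gap between the two values is not tied to any single change, and only the two numbers themselves can be set side by side. Compound 3 `NC(=O)c1ccc(-c2cccnc2)cc1OC1CCC1` has not yet been measured in this assay. It differs from compound 1 by cyclobutyl in place of pyrrolidin-3-yl on an oxygen on an aromatic ring. Among the measured compounds shown here, no measured pair shows what the exchange of pyrrolidin-3-yl for cyclobutyl does in this assay. A loss of inhibition of modest size, beyond the usual scatter but with wide uncertainty, is expected for the step of a 2.6-fold higher number from compound 1 to compound 3 (0.42 log units; beyond the scatter). Compound 3 is estimated at 5000 nM, with a range from 1500 nM to 20000 nM.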

Compound 3, half-maximal inhibitory concentration: 1900 nM
The estimate for compound 3 lay 2.6-fold (0.42 log units) above the measured number; the range from low to high includes it.
By their numbers in this assay, from the lowest: compounds 1 and 3 (each within the scatter of the next); then compound 2.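

In this assay, among the compounds shown here, the exchange of pyrrolidin-3-yl for cyclobutyl on an oxygen on an aromatic ring gives no change at the digits printed from compound 1 to compound 3 (within the scatter) and provides the first single-place comparison. At this position, the ring nitrogen and the hydrogen-bond donor and acceptor counted with pyrrolidin-3-yl can therefore leave without a change beyond the scatter, and a four-membered ring of carbon only takes the place of the five-membered ring with its hetero atom. No available evidence bears on the reason for this result.

The shown compounds cover only these two rings on this oxygen, so one tolerated exchange sets no limit on what the position accepts. Going by these compounds, whether a longer chain ending in an amine, a carboxylic acid or a cyclohexyl ring would leave the number in the same place remains open.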